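The source may hold more compounds than are shown below. What is called first, only, known or untested is meant among the compounds shown, and "the series" means these compounds.

Measured compounds:
compound 1, `CCCCNC(=O)NS(=O)(=O)c1ccc(-n2nc(C)cc2C)cc1`: 2%
compound 2, `CCCCNC(=O)NS(=O)(=O)c1ccc(-n2nc(C(=O)O)cc2C)cc1`: 2%

In a functional assay on the whole organism (blood, strain albino) with Mus musculus as the target, with stated times of 6 days and 4 h, at a dose of 0.4 mmol/kg by the oral route (a higher number here means more inhibition at the dose given (going by the name of the read-out), a lower number less inhibition), compound 1 gives 2%, and compound 2 gives 2%, so the two stand level at the digits shown. Among the compounds with values here, the only measured step, no change at the digits printed from compound 1 to compound 2 (within the scatter), lies within the scatter, which leaves compound 1 neither above nor below any other measured compound in this assay.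

Compound 3, `CCCNC(=O)NS(=O)(=O)c1ccc(-n2nc(C)cc2C)cc1`, has not yet been measured in this assay. It differs from compound 1 by hydrogen in place of methyl on a saturated chain carbon, three bonds along the chain from an amide-type nitrogen. Within the data shown here, no measured step bears on this particular change: the only step available concerns a carboxy in place of a methyl on an aromatic carbon, and it was flat. With compound 1 already at a very low level, there is little room for a step downward, and nothing in the data suggests a step upward, so no change beyond the scatter is expected, no change at the digits printed from compound 1 to compound 3 (within the scatter). Compound 3 is therefore estimated to give 2% in this assay, with a range from -8% to 12%.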

Compound 3, a percentage reported as inhibition, in the whole organism at one dose (the size of the read-out at that dose, not a potency): < 1%
Compound 3 ended at the assay's limit (the forecaster's own chance of this, stated with the estimate: 3%); middle value at least 1 percentage points from the limit.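

Within the data shown here, the earlier compounds changed only an aromatic carbon, whereas compound 3 is the first to change the butyl chain on the urea side of the molecule, replacing butyl with propyl. In this assay this change gives a number at least 1 percentage points lower from compound 1 to compound 3 (that floor lies within the scatter), so shortening the chain at this place, three bonds along from an amide-type nitrogen, brings no gain in inhibition at the dose given. Compound 3 reads < 1%, which is a limit of the assay and not a number, so the step has a floor but no known full size: the limit of < 1% in this assay, at which 1 of the 3 values shown sits.

From the compounds shown here alone, whether a longer chain such as pentyl, or an amine or a carboxylic acid at the end of the chain, would change the inhibition remains open. Also open, going by these compounds, is how this position behaves in a compound that stands well clear of the limit.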